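The source may report more compounds than this note shows. Statements on the series, on what has been measured and on what is new or still open speak of the compounds shown alone.

Of the compounds shown here, three sharing one core have been tested in a functional assay on cells (Platelet, Homo sapiens) for inhibition (a lower number here means a stronger inhibitor, a higher number a weaker inhibitor), and none has yet given a number. Compound 1 `CCOC(=O)c1ccc(-c2nn(Cc3ccccc3F)c3ccccc23)cc1` reads > 10000 nM, which is a limit of the assay and not a measured value. Compound 2 `CCOC(=O)c1ccc(-c2nn(Cc3ccc(F)cc3)c3ccccc23)cc1` reads > 10000 nM, also a limit. Compound 3 `CCOC(=O)c1cccc(-c2nn(Cc3ccccc3)c3ccccc23)c1` reads > 10000 nM, again a limit. Compound 2 therefore stands level with the others on what can be read: the limit of > 10000 nM in this assay, at which 3 of the 3 values shown sit.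

Compound 4 `CCOC(=O)c1ccc(-c2nn(Cc3ccncc3)c3ccccc23)cc1` has pyridin-4-yl in place of 4-fluorophenyl on a saturated chain carbon bound to an aromatic nitrogen. Going by the values given here, the one measured step at this place is a step that the two limits leave unreadable from compound 1 to compound 2, so it offers no size to carry over to the new change. Among the compounds with values here, no step of readable size is therefore expected in this assay, in either direction, and compound 4 will most likely report only a limit too. The expected change is a step that the limit leaves unreadable from compound 2 to compound 4. For compound 4 the estimated value is 12000 nM, with an expected range from 4000 nM to 30000 nM.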

Compound 4, half-maximal inhibitory concentration: > 10000 nM
Compound 4 ended at the assay's limit; the forecaster's own chance of this, stated with the estimate: 75%; the middle value does not contradict the limit.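

No step can be read from compound 2 to compound 4 or from compound 1 to compound 4, since each compound gives only a limit in this assay: the limit of > 10000 nM in this assay, at which 4 of the 4 values shown sit.

The compounds shown leave open how these groups truly compare, and whether any change to the shared core would give a measured number.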